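Indole oxalamides: cytotoxicity on head-and-neck cells, next variant

The source may hold more compounds than are shown below. What is called first, only, known or untested is meant among the compounds shown, and "the series" means these compounds.

Two members of the series carry a measured number. Compound 1 `COc1ccc(NC(=O)C(=O)c2cn(CC(C)C)c3ccccc23)cn1` has the lowest of the two values: in a functional assay on FaDu cells (Homo sapiens) for cytotoxicity, read by MTT assay, with a stated time of 72 h (a lower number here means that less compound is tolerated, a higher number that more compound is tolerated), compound 1 gives 317 nM. Compound 2 `CC(C)n1cc(C(=O)C(=O)Nc2ccc(OC(F)(F)F)cc2)c2ccccc21` differs from it in more than one place, and in this assay compound 2 gives 8930 nM, a value that stands well beyond the scatter from that of compound 1. Within the data shown here, no single-point comparison between measured compounds is available, so the change below has no precedent within the set.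

Compound 3 `COCC(C)(C)n1cc(C(=O)C(=O)Nc2ccc(OC)nc2)c2ccccc21` is the next variant of compound 1. The change is 1-(methoxymethyl)-1-methylethyl in place of isobutyl on an aromatic nitrogen. Both groups sit on the same aromatic nitrogen, and neither carries a charge or a donor.

Among the measured compounds shown here, with no measured step of this kind to lean on, a modest shift is expected, toward a higher number if any. Compound 3 is estimated at 550 nM, with a range from 150 nM to 2000 nM. This estimate means a step of a 1.7-fold higher number from compound 1 to compound 3 (0.24 log units; within the scatter), expected to stay near the scatter.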

Compound 3, concentration lethal to 50% of the cells: 137 nM
Compound 3: the middle estimate sits 4.0-fold (0.60 log units) above what was measured, and the stated range ends above it.
By their numbers in this assay, from the lowest: compound 3; then compound 1; then compound 2.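

In this assay, the aromatic nitrogen accepts 1-(methoxymethyl)-1-methylethyl in place of isobutyl without any loss, giving a 2.3-fold lower number from compound 1 to compound 3 (0.36 log units; beyond the scatter). Among these compounds, this is the first single-place step, so this position now has a measured effect of its own with the rest of compound 1 held fixed, and the direction runs opposite to the shift toward a higher number that seemed more likely. Nothing available explains the step.

The change alters the branching of the chain and adds an oxygen in one move, so the compounds shown cannot say which of the two carries the step. A tert-butyl group or a plain 2-methoxyethyl chain on this nitrogen would separate them, and a dimethylamino group in place of the methoxy would test whether the oxygen can be exchanged at all.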